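From Trifluoromethyl to Trifluoromethoxy in Compound 3

The source may report more compounds than this note shows. Statements on the series, on what has been measured and on what is new or still open speak of the compounds shown alone.

Measured so far in a functional assay on VCaP cells (Homo sapiens) for antiproliferative activity, read by propidium iodide staining, with a stated time of 96 h (on this read-out lower numbers stand for stronger inhibition and higher numbers for weaker inhibition), are two compounds:
- compound 1 `CC(O)(CSc1cccc(S(F)(F)(F)(F)F)c1)C(=O)Nc1cccc(S(F)(F)(F)(F)F)c1` gives 29000 nM here
- compound 2 `CC(O)(CSc1cccc(C(F)(F)F)c1)C(=O)Nc1cccc(S(F)(F)(F)(F)F)c1` gives 20200 nM here

Compound 2 lies within the usual scatter of compound 1 and so cannot be ranked against it. Compound 3 `CC(O)(CSc1cccc(OC(F)(F)F)c1)C(=O)Nc1cccc(S(F)(F)(F)(F)F)c1` keeps the rest of compound 2 and differs by one swap, trifluoromethoxy in place of trifluoromethyl on an aromatic carbon and nothing else. Within the data shown here, only one measured step bears on this swap. It is a 1.4-fold lower number from compound 1 to compound 2 (0.16 log units; within the scatter) and it also exchanged a group on an aromatic carbon. Among the measured compounds shown here, no measured compound yet carries trifluoromethoxy, so this is thin evidence. With that single step as the guide, no change beyond the scatter is expected in this assay for this swap. The expected step is a 1.0-fold lower number from compound 2 to compound 3 (0.00 log units; within the scatter) on this estimate. Compound 3 is estimated at 20000 nM with an expected range from 9000 nM to 40000 nM in this read-out.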

Compound 3, half-maximal inhibitory concentration: 17500 nM
The estimate for compound 3 lay 1.1-fold (0.06 log units) above the measured number; the range from low to high includes it.
By their numbers in this assay, from the lowest: compounds 3, 2 and 1 (each within the scatter of the next).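

Trifluoromethoxy brings an oxygen and a hydrogen-bond acceptor that trifluoromethyl lacks, yet in this assay this swap gives a 1.2-fold lower number from compound 2 to compound 3 (0.06 log units; within the scatter) and so cannot be told apart from no change. The wider exchange for the group of 6 heavy atoms, made of sulfur and fluorine, gives a 1.7-fold lower number from compound 1 to compound 3 (0.22 log units; within the scatter) and also stays within the scatter, so none of the three groups at this aromatic carbon can be ranked above another. Nothing available here offers an explanation for this similarity.

On these data alone, all three groups contain fluorine and carry no net charge, so it remains open whether an amine, a carboxylic acid or a plain hydrogen at this carbon would move the number beyond the scatter. As far as these compounds go, it also remains open whether a change elsewhere on the shared core would matter more.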